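The source may report more compounds than this note shows. Statements on the series, on what has been measured and on what is new or still open speak of the compounds shown alone.

Three compounds share a core and differ only in the group on an amide-type nitrogen. Compound 1 `CNC(=O)CC1CCc2cc(OC)c(OC)cc21` carries methyl there, compound 2 `COc1cc2c(cc1OC)C(CC(=O)NC(C)C)CC2` isopropyl and compound 3 `COc1cc2c(cc1OC)C(CC(=O)NC1CCCCC1)CC2` cyclohexyl. In a functional assay on the whole organism (strain Wistar) for inhibition, with Rattus norvegicus as the target, read by paw edema, with stated times of 60 min and 4 h, at a dose of 100 mg/kg by the oral route (on this read-out higher numbers stand for more inhibition at the one dose given (going by the name of the read-out) and lower numbers for less inhibition), compound 1 gives 29.7%, compound 2 gives 39.1% and compound 3 gives 50%. Compound 2 therefore stands second highest of the three numbers; its gap to compound 1, a number 9.4 percentage points higher from compound 1 to compound 2 (within the scatter), lies within the scatter, whereas the step to compound 3, a number 10.9 percentage points higher from compound 2 to compound 3 (beyond the scatter), lies beyond it, as does a number 20.3 percentage points higher from compound 1 to compound 3 (beyond the scatter).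

Compound 4 `COc1cc2c(cc1OC)C(CC(=O)NCc1ccccc1)CC2` is the next step from compound 2: benzyl in place of isopropyl on an amide-type nitrogen The change keeps the place on the amide-type nitrogen beside the carbonyl carbon, with isopropyl leaving and benzyl entering. Among the compounds with values here, the steps that bear on it are the two in which the group on that nitrogen grew, one modest and beyond the scatter, one within it. Compound 4 is therefore expected to show a modest rise, a number 8.9 percentage points higher from compound 2 to compound 4 (within the scatter), in this assay. The estimated value of compound 4 is 48%, within a range from 36% to 60%.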

Compound 4, a percentage reported as inhibition, in the whole organism at one dose (the size of the read-out at that dose, not a potency): 18.8%
Estimate against measurement, compound 4: 29.2 percentage points above; measured number outside the range, below it.
By their numbers in this assay, from the lowest: compound 4; then compounds 1 and 2 (each within the scatter of the next); then compound 3.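

In this assay the higher numbers that came with going from methyl to cyclohexyl on the amide-type nitrogen do not extend to benzyl: the change gives a number 20.3 percentage points lower from compound 2 to compound 4 (beyond the scatter), and against the cyclohexyl amide it gives a number 31.2 percentage points lower from compound 3 to compound 4 (beyond the scatter). Even the methyl amide stands higher, with a number 10.9 percentage points lower from compound 1 to compound 4 (beyond the scatter), so compound 4 is the lowest of the four, and a larger group at this place does not by itself bring more inhibition. Nothing available explains this reversal.

The compounds shown leave open whether the fall goes with the six-membered aromatic ring or with the chain carbon that joins it to the nitrogen. A cyclohexylmethyl, phenyl or phenethyl group on that nitrogen would separate these two readings.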